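Three Cytotoxicity Limits and a Fourth Compound to Judge

The source may report more compounds than this note shows. Statements on the series, on what has been measured and on what is new or still open speak of the compounds shown alone.

Compound 1 `CC(C)N(Cc1cccc(OCCCCCC(=O)O)c1)C(=O)c1ccc(-c2cccc(N(C)C)c2)cc1`, compound 2 `CCOC(=O)CCCCCOc1cccc(CN(C(=O)c2ccc(-c3cnc(OC)nc3OC)cc2)C(C)C)c1` and compound 3 `CCOC(=O)CCCCCOc1cccc(CN(C(=O)c2ccc(-c3cc4ccccc4n3S(=O)(=O)c3ccccc3)cc2)C(C)C)c1` were all tested in an ADME assay on HepG2 cells (Homo sapiens) for cytotoxicity, read by CellTiter-Glo and resazurin assay, with a stated time of 72 h; on this read-out higher numbers stand for an effect only at larger amounts of compound and lower numbers for an effect already at smaller amounts. In this assay compound 1 reports only a limit of the assay, > 26000 nM. Compound 2 likewise gives only a limit, > 26000 nM. Compound 3 also stops at a limit, > 26000 nM. Compound 2 therefore stands where every value shown stands, because of the limit of > 26000 nM in this assay, at which 3 of the 3 values shown sit. Compound 4 `CCOC(=O)CCCCCOc1cccc(CN(C(=O)c2ccc(-c3cccc(C(F)(F)F)c3)cc2)C(C)C)c1` has not been tested yet. It differs from compound 2 in one place: 3-(trifluoromethyl)phenyl in place of 2,4-dimethoxypyrimidin-5-yl on an aromatic carbon. Going by the values given here, with no measured step to compare, the expected change in this assay is none beyond the scatter, so compound 4 is expected to give 30000 nM, within 12000 nM to 80000 nM, an expected step that the limit leaves unreadable from compound 2 to compound 4.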

Compound 4, half-maximal effective concentration: > 26000 nM
Compound 4: only a limit was reported; the forecaster's own chance of this, stated with the estimate: 80%; the middle value lies beyond the limit too.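

Compound 2 and compound 4 each give only a limit in this assay, and the step between them cannot be read. The compounds shown leave open what amount of any of them would actually affect these cells.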